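The compounds below may be only part of what the source reports. "The series", "measured", "known", "first", "only" and "open" are said of these compounds alone.

Compound 1 `N#Cc1ccc(NC(=O)c2cc(-c3ccncc3)ccc2O)cc1` holds the higher of the two numbers shown: in a functional assay on KG-1 cells (Homo sapiens) for cytotoxicity, read by luminescence and CellTiter-Glo, with a stated time of 3 days (a lower number here means a stronger inhibitor, a higher number a weaker inhibitor), compound 1 gives 7990 nM. The nearest neighbour of compound 1 is compound 3 `Cc1cc(C#N)ccc1NC(=O)c1ccc2cccnc2c1O`, and compound 3 gives 3240 nM, a gap that lies beyond the usual scatter. Compound 2 `N#Cc1ccc(Nc2n[nH]c3ccccc23)cc1` reaches only the limit of this assay, > 10000 nM, and no number. One of the three values shown is thus such a limit (the limit of > 10000 nM in this assay, at which 1 of the 3 values shown sits).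

Compound 4 `N#Cc1ccc(NC(=O)c2ccccc2O)cc1` has not been measured in this assay. It differs from compound 1 in one place: hydrogen in place of pyridin-4-yl on an aromatic carbon. Among the compounds with values here, no two measured compounds differ from each other in a single place, so there is no measured step to lean on; compounds 1 and 3 differ in the shared core and in more than one group at once.

The pyridin-4-yl that leaves is a substantial part of compound 1, and compound 1 is already the weaker of the two numbers shown. The expected step from compound 1 to compound 4 is a 1.9-fold higher number from compound 1 to compound 4 (0.27 log units; within the scatter), towards a weaker inhibitor and of a size that may exceed the scatter. Compound 4 is therefore estimated to give 15000 nM in this assay, within 5000 nM to 50000 nM, with a fair chance that only a limit is reported.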

Compound 4, half-maximal inhibitory concentration: 5370 nM
The estimate for compound 4 lay 2.8-fold (0.45 log units) above the measured number, and the stated range covers the measured number.
By their numbers in this assay, from the lowest: compounds 3, 4 and 1 (each within the scatter of the next, the first and the last beyond it). At a limit, above all of these: compound 2.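

In this assay, within the data shown here, the first single-place step reads a 1.5-fold lower number from compound 1 to compound 4 (0.17 log units; within the scatter), with hydrogen in place of pyridin-4-yl on an aromatic carbon para to a hydroxy group. This position can therefore carry either a whole six-membered aromatic ring or a bare hydrogen without a difference that this read-out separates from the scatter, so pyridin-4-yl, for all its size, has no measurable part in the number at this level of activity. Nothing measured here gives a reason for this outcome.

The compounds shown leave open whether a small group on this aromatic carbon, such as an amine, a methoxy group or a carboxylic acid, would move the number beyond the scatter, as hydrogen and pyridin-4-yl are the only two groups compared at this position. Also open, as far as these compounds go, is what the hydroxy group and the nitrile of compound 4 contribute, for instance with a methoxy group in place of the hydroxy group or a carboxylic acid in place of the nitrile.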